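The source may report more compounds than this note shows. Statements on the series, on what has been measured and on what is new or still open speak of the compounds shown alone.

In a physicochemical assay for lipophilicity (a higher number here means a more lipophilic compound, a lower number a more polar compound), compound 1 `FCCCN1CCC(COc2c(F)c(F)c(F)c(F)c2F)CC1` gives 4.11 and compound 2 `N#Cc1ccc(OCC2CCN(Cc3ccccc3I)CC2)cc1` gives 4.3. Within the data shown here, these two values lie within the scatter of each other, so compound 1 cannot be ranked against the only other measured compound. Compound 3 `Fc1cccc(CN2CCC(COc3c(F)c(F)c(F)c(F)c3F)CC2)c1` keeps the core of compound 1 and carries one change, 3-fluorophenyl in place of 2-fluoroethyl on a saturated chain carbon bound to an amine nitrogen in a ring. Among the measured compounds shown here, no measured pair covers this change, so the expectation rests on the structural change alone. The expected step, a number 0.69 log units higher from compound 1 to compound 3 (beyond the scatter), is upward and beyond the scatter in this assay. For compound 3 the estimated value is 4.8, with an expected range of 4.3 to 5.3.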

Compound 3, partition coefficient: 4.72
For compound 3 the middle estimate is 0.08 log units above the measured one; the range from low to high includes it.
By their numbers in this assay, from the lowest: compounds 1 and 2 (each within the scatter of the next); then compound 3.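

At this position, on a saturated chain carbon bound to an amine nitrogen in a ring, 3-fluorophenyl in place of 2-fluoroethyl moves this assay by a number 0.61 log units higher from compound 1 to compound 3 (beyond the scatter) with the rest of the core of compound 1 unchanged. Among these compounds, this is the first single-place comparison, and it shows that the reading responds to a change here. No evidence on the origin of the step is available.

The step alone does not separate the aromatic ring from the fluorine or from the added heavy atoms. Cyclohexyl or unsubstituted phenyl at this position, or a carboxylic acid on the chain, remains open.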